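Swapping a phenethyl for a cyclopentyl in a cathepsin S inhibitor

The source may report more compounds than this note shows. Statements on the series, on what has been measured and on what is new or still open speak of the compounds shown alone.

Measured so far:
- compound 1, `C[C@@H](CNc1ccc(OC(F)(F)F)cc1)NC(=O)[C@@H](CC(=O)N1CCOCC1)CC1CCCC1`: 31 nM
- compound 2, `CC(C)[C@@H](CNc1ccc(OC(F)(F)F)cc1)NC(=O)[C@H](CCCc1ccccc1)CC(=O)N1CCOCC1`: 14 nM
- compound 3, `C[C@@H](CN1CCc2cc(F)ccc21)NC(=O)[C@@H](CC(=O)N1CCOCC1)Cc1ccccc1`: > 24000 nM

In an assay on isolated protein for inhibition of cathepsin S (Homo sapiens) (a higher number here means a weaker inhibitor, a lower number a stronger inhibitor), compound 2 gives 14 nM, the lowest of the two numbers shown; compound 1 sits at 31 nM, a gap beyond the scatter. Compound 3 reports only a limit in this assay, > 24000 nM, so no number is known for it. Compound 4, `CC(C)[C@@H](CNc1ccc(OC(F)(F)F)cc1)NC(=O)[C@@H](CC(=O)N1CCOCC1)CC1CCCC1`, has not yet been measured. It differs from compound 2 in one place: cyclopentyl in place of phenethyl on a saturated chain carbon, two bonds along the chain from a carbonyl carbon. Compound 1 already carries this cyclopentyl group on a core that otherwise differs from compound 4 only elsewhere, and its number is close to that of compound 2. The step from compound 2 to compound 4 is therefore expected to be small, a 1.6-fold higher number from compound 2 to compound 4 (0.20 log units; within the scatter), slightly weaker or within the scatter. Compound 4 is estimated at 22 nM, between 8 nM and 60 nM.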

Compound 4, inhibition constant: 38 nM
Estimate against measurement, compound 4: 1.7-fold (0.24 log units) below, within the range that was stated.
By their numbers in this assay, from the lowest: compound 2; then compounds 1 and 4 (each within the scatter of the next). At a limit, above all of these: compound 3.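

In this assay, cyclopentyl in place of phenethyl at this saturated chain carbon weakens binding only modestly, with a 2.7-fold higher number from compound 2 to compound 4 (0.43 log units; beyond the scatter) as the measured step. The position therefore tolerates this smaller, non-aromatic ring, and with cyclopentyl in place, isopropyl in place of methyl gives no change that can be told from scatter, with a 1.2-fold higher number from compound 1 to compound 4 (0.09 log units; within the scatter) as the step. Nothing shown here explains the loss on leaving phenethyl. Open, going by these compounds, is how a cyclohexyl group or a plain butyl chain would behave at this carbon. An amine at the end of the chain is equally untested among these compounds.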